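Trifluoromethyl to ethoxycarbonyl on the phenylurea series

The source may hold more compounds than are shown below. What is called first, only, known or untested is meant among the compounds shown, and "the series" means these compounds.

Measured so far in an ADME assay on the whole organism with Oryza sativa as the target, tested at 1 uM; on this read-out higher numbers stand for a weaker effect at the one concentration tested and lower numbers for a stronger effect: compound 1 `C[C@@H](NC(=O)Nc1cccc(C(F)(F)F)c1)c1ccccc1` gives 72%; compound 2 `C[C@@H](NC(=O)Nc1ccc(C(F)(F)F)cc1)c1ccccc1` gives 89%; compound 3 `CCOC(=O)c1cccc(NC(=O)N[C@H](C)c2ccccc2)c1` gives 94%.

Compounds 1 and 2 share the same atoms joined differently; the difference between the two cores is not broken down here. From compound 1 to compound 3 the change is ethoxycarbonyl in place of trifluoromethyl on an aromatic carbon, and it made a number 22 percentage points higher from compound 1 to compound 3 (beyond the scatter). The same kind of change, (ethoxycarbonyl in place of trifluoromethyl on an aromatic carbon), leads from compound 2 to compound 4 `CCOC(=O)c1ccc(NC(=O)N[C@H](C)c2ccccc2)cc1`, the only difference around the place being that the ethoxycarbonyl sits para to a large group rather than meta to it. Compound 2 already stands close to compound 3 in this assay, and a read-out in percent cannot climb far, so the step is expected to be smaller: a number 8 percentage points higher from compound 2 to compound 4 (within the scatter). Compound 4 is estimated at 97%, between 88% and 100%.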

Compound 4, a percentage reported as activity, at one concentration (the size of the read-out at that concentration, not a potency): 100%
Compound 4: middle estimate off by 3 percentage points, on the low side; the range from low to high includes it.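

Ethoxycarbonyl in place of trifluoromethyl in this assay makes a number 11 percentage points higher from compound 2 to compound 4 (beyond the scatter) and so moves the number the same way on both cores, towards a weaker effect at the one concentration tested. The size of the step also carries over, as far as the scatter allows: the same change on two cores in this assay, a number 22 percentage points higher (beyond the scatter) from compound 1 to compound 3 and a number 11 percentage points higher (beyond the scatter) from compound 2 to compound 4, 11 percentage points apart, within the scatter of two such steps
This rests on two pairs only, so it shows that direction and size held on these two cores, but not why, nor that they would hold on any other core.

Open, going by these compounds, is whether a carboxylic acid, a nitrile or an amine on that aromatic carbon would move the number the same way. Also open, on these data alone, is whether a longer chain on the ester, such as propoxycarbonyl, would do so.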